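The compounds below may be only part of what the source reports. "The series", "measured", "known", "first", "only" and "open" are said of these compounds alone.

Working notes on the series. All three measured members carry the same shared core, an enone linking a triazole to an anilide, and all were tested in a functional assay on HeLa cells (Homo sapiens) for inhibition, read by MTT assay; on this read-out lower numbers stand for stronger inhibition and higher numbers for weaker inhibition. Compound 1 `CCCCCCCCn1cc(/C=C/C(=O)c2ccc(NC(=O)CN3CCN(c4ccccc4F)CC3)cc2)nn1` gives 33800 nM in this assay. Compound 3 `CC(C)(C)OC(=O)N1CCN(CC(=O)Nc2ccc(C(=O)/C=C/c3cn(Cc4ccc(Br)cc4)nn3)cc2)CC1` gives 18900 nM, a number within the scatter of compound 1, so the two cannot be ordered. Compound 2 `CCCCCCCCCCn1cc(/C=C/C(=O)c2ccc(NC(=O)CN3CCC(Cc4ccccc4)CC3)cc2)nn1` gives 71700 nM, which stands higher than the number of compound 1 by more than the scatter, so of these three compound 1 holds the second highest number, close to compound 3 and clearly apart from compound 2.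

Compound 4 `CCCCCCCCn1cc(/C=C/C(=O)c2ccc(NC(=O)CN3CCN(c4ccccc4)CC3)cc2)nn1` has not been measured in this assay. It differs from compound 1 in a single place: hydrogen in place of fluoro on an aromatic carbon. The change removes one heavy atom and leaves the rest of the molecule untouched; nothing measured in the series speaks to this exact change. The step from compound 1 to compound 4 is therefore expected to be small, a 1.0-fold higher number from compound 1 to compound 4 (0.02 log units; within the scatter), not beyond the scatter in either direction. On that basis compound 4 is estimated at 35000 nM in this assay, with a range from 15000 nM to 80000 nM.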

Compound 4, half-maximal inhibitory concentration: 33800 nM
Compound 4: the middle estimate sits 1.0-fold (0.02 log units) above what was measured; the measured number falls inside the stated range.
By their numbers in this assay, from the lowest: compounds 3, 1 and 4 (each within the scatter of the next); then compound 2.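

In this assay, going by these compounds alone, the change from 2-fluorophenyl to phenyl gives no change at the digits printed from compound 1 to compound 4 (within the scatter) and is the first comparison of compounds that differ in one place, which the earlier compounds could not provide. At this aromatic carbon, ortho to a large group, fluoro and hydrogen cannot be told apart on this read-out, so for this pair the fluorine atom is not required for the number seen with compound 1. Nothing at hand explains this outcome.

The compounds shown leave open whether chloro, methoxy or trifluoromethyl on the same aromatic carbon would also leave the number within the scatter. They also leave open whether the same exchange of fluoro for hydrogen would read the same with a dodecyl chain in place of the octyl chain.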